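The source may report more compounds than this note shows. Statements on the series, on what has been measured and on what is new or still open speak of the compounds shown alone.

Among the compounds with values here, in a functional assay on HL-60 cells (Homo sapiens) for antiproliferative activity, read by MTT assay, with a stated time of 48 h (on this read-out higher numbers stand for weaker inhibition and lower numbers for stronger inhibition), three compounds sharing one core have numbers so far. Compound 1 `CC(=O)OC/C1=C/C[C@](C)(CCC=C(C)C)/C=C/[C@@H](OC(=O)C=C(C)C)[C@](C)(OC(C)=O)/C=C/C1=O` gives 3480 nM and compound 2 `CC(C)=CCC[C@]1(C)/C=C/[C@@H](OC(=O)C=C(C)C)[C@](C)(O)/C=C/C(=O)/C(CN2CCN(C)CC2)=C\C1` gives 840 nM while compound 3 `CC(C)=CCC[C@]1(C)/C=C/[C@@H](OC(=O)C=C(C)C)[C@](C)(O)/C=C/C(=O)/C(COC(=O)c2ccc([N+](=O)[O-])cc2)=C\C1` gives 830 nM on the same scale. Compound 2 sits with compound 3 at the low end of these numbers, the two lying within the scatter, and compound 1 has the higher number.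

Compound 4 `CC(C)=CCC[C@]1(C)/C=C/[C@@H](OC(=O)C=C(C)C)[C@](C)(O)/C=C/C(=O)/C(C(=O)N(C)C)=C\C1` has not been measured and carries dimethylcarbamoyl in place of (4-methylpiperazin-1-yl)methyl on a double-bonded ring carbon. Within the data shown here, in full the difference reads dimethylcarbamoyl in place of (4-methylpiperazin-1-yl)methyl on a double-bonded ring carbon and no measured compound carries dimethylcarbamoyl. Among the measured compounds shown here, the one measured step that bears on it is a 1.0-fold lower number from compound 2 to compound 3 (0.01 log units; within the scatter) for ((4-nitrophenyl)carbonyl)oxy in place of 4-methylpiperazin-1-yl on a saturated chain carbon bound to a double-bonded ring carbon. That step is small, but compound 4 also lacks that saturated chain carbon, so a single step gives thin support and the range stays wide. The estimated move is a 1.2-fold higher number from compound 2 to compound 4 (0.08 log units; within the scatter) and so no shift beyond the scatter is expected in either direction. For compound 4 in this assay the estimate is 1000 nM with 400 nM to 2800 nM as the expected range.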

Compound 4, half-maximal inhibitory concentration: 3340 nM
The estimate for compound 4 lay 3.3-fold (0.52 log units) below the measured number, outside the stated range (above it).
By their numbers in this assay, from the lowest: compounds 3 and 2 (each within the scatter of the next); then compounds 4 and 1 (each within the scatter of the next).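

In this assay the double-bonded ring carbon does not accept every group equally: dimethylcarbamoyl in place of (4-methylpiperazin-1-yl)methyl gives a 4.0-fold higher number from compound 2 to compound 4 (0.60 log units; beyond the scatter), a step beyond the scatter. The earlier change on the saturated chain carbon, a 1.0-fold lower number from compound 2 to compound 3 (0.01 log units; within the scatter), stayed within the scatter, so replacing what that carbon carries had not yet moved the number, whereas the new change, which also removes that carbon, does. Nothing in the data shown explains this shift.

The compounds shown do not separate the loss of the saturated chain carbon from the loss of the piperazine ring. A dimethylaminomethyl group, which keeps that carbon without the ring, and a 4-methylpiperazine-1-carbonyl group, which keeps the ring on a carbonyl, would pull these two changes apart.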